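The source may hold more compounds than are shown below. What is called first, only, known or untested is meant among the compounds shown, and "the series" means these compounds.

Compound 1 `Cc1cc2ncc(S(=O)(=O)c3ccccc3)c(-c3ccccc3)n2n1` and compound 2 `Cc1nn2c(-c3ccccc3)c(S(=O)(=O)c3ccccc3)cnc2c1Br` share one core; compound 3 `Cc1ccc(-c2c(S(=O)(=O)c3ccccc3)cnc3cc(-c4ccccc4)nn23)cc1` and compound 4 `Cc1ccc(-c2c(S(=O)(=O)c3ccccc3)cnc3c(Br)c(-c4ccccc4)nn23)cc1` share another, and the difference between the two cores is not broken down here. All four belong to a functional assay on HCT-116 cells (Homo sapiens) for cytotoxicity, read by sulforhodamine B assay, with a stated time of 48 h; on this read-out lower numbers stand for stronger inhibition and higher numbers for weaker inhibition.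

Compound 1 gives only a limit in this assay, > 25 ug/mL (the limit of > 25 ug/mL in this assay, at which 1 of the 3 values shown sits). Compound 2 gives 2.21 ug/mL. The change from compound 1 to compound 2 is bromo in place of hydrogen on an aromatic carbon, and it brings an at least 11-fold lower number from compound 1 to compound 2 (1.05 log units; beyond the scatter). Compound 3 gives 18 ug/mL in this assay.

Compound 4 differs from compound 3 by bromo in place of hydrogen on an aromatic carbon. This is the same kind of change as that from compound 1 to compound 2, though the surroundings differ: in compound 2 the bromo sits next to the ring atom that bears a methyl group, while in compound 4 it sits next to the ring atom that bears a phenyl group. From the compounds shown here alone, the earlier step starts from a limit, so its full size is unknown, and the two cores differ. Within the data shown here, still, the one measured example points one way, so for compound 4 a step of about a 7.2-fold lower number from compound 3 to compound 4 (0.86 log units; beyond the scatter) is expected. Compound 4 is thus estimated at 2.5 ug/mL, with a likely range from 0.8 ug/mL to 8 ug/mL.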

Compound 4, half-maximal inhibitory concentration: 14 ug/mL
Beside the measured number, compound 4's estimate is 5.6-fold (0.75 log units) below it, and the stated range ends below it.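

In this assay, bromo in place of hydrogen on an aromatic carbon brings only a 1.3-fold lower number from compound 3 to compound 4 (0.11 log units; within the scatter), so the large step seen on the first core does not carry over in size to the second: the same change on two cores in this assay, an at least 11-fold lower number (1.05 log units; beyond the scatter) from compound 1 to compound 2 and a 1.3-fold lower number (0.11 log units; within the scatter) from compound 3 to compound 4, at least 8.7-fold (0.94 log units) apart, beyond the scatter of two such steps. Compound 1 gives only a limit, > 25 ug/mL, and not a number. These two pairs show that the same bromo change can give very different steps on different cores in this series, but they do not show why, or what the change would do on a third core.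

The compounds shown leave open whether chloro, iodo, an amine or a carboxylic acid in the bromo position would follow the pattern of either core. They also leave open which part of the difference between the two cores goes with the gap, as no pair shown changes that part alone.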